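This account rests on a few compounds, and the source may have more. Where it says the series, first, only, none or still open, it means among the compounds named here.

Compound 1 `Cn1c(-c2ccccc2C(F)(F)F)nnc1C12CCC(COc3ccc(S(C)(=O)=O)cc3)(CC1)CC2` gives > 4000 nM in an assay on CHO-K1 cells for inhibition of 11-beta-hydroxysteroid dehydrogenase type 2 (Mus musculus), read by scintillation proximity assay (a lower number here means a stronger inhibitor, a higher number a weaker inhibitor), which is a limit of the assay and not a number.
Compound 2 `CCOCC12CCC(c3nnc(-c4ccccc4C(F)(F)F)n3C)(CC1)CC2` gives > 4000 nM in this assay, again a limit rather than a number.

Compound 2 therefore stands only at a limit, and both measured values sit there (the limit of > 4000 nM in this assay, at which 2 of the 2 values shown sit). Among the compounds with values here, the one measured step, a step that the two limits leave unreadable from compound 1 to compound 2, replaced 4-(methylsulfonyl)phenyl with ethyl on an oxygen on a saturated carbon, and the two limits leave its size unreadable. Compound 3 `CC(F)CCCC12CCC(c3nnc(-c4ccccc4C(F)(F)F)n3C)(CC1)CC2` differs from compound 2 by 3-fluorobutyl in place of ethoxy on a saturated chain carbon bound to a saturated ring carbon. Within the data shown here, no measured step speaks readably to this change, so no direction or size beyond the usual scatter can be drawn from the numbers. The expectation for compound 3 is that it again lands at a limit in this assay, and the estimate is 8000 nM, with a range from 2000 nM to 40000 nM. This estimate for compound 3 implies an expected step that the limit leaves unreadable from compound 2 to compound 3.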

Compound 3, half-maximal inhibitory concentration: > 4000 nM
Compound 3: only a limit was reported; the forecaster's own chance of this, stated with the estimate: 80%; the middle value does not contradict the limit.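

Compound 3 gives > 4000 nM in this assay, a limit of the assay and not a number. Its steps from compound 1 and compound 2 therefore cannot be read: the limit of > 4000 nM in this assay, at which 3 of the 3 values shown sit.

The compounds shown leave open how strongly any of them inhibits, and which group in this place on the shared core, if any, would give a readable number.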